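A few compounds are considered here, and "the series" means these few. Any claim that something is new, unique, unknown or untested is made for them only; others in the source may bear on it.

Measured so far:
compound 1, `COc1cc(N)c(Cl)cc1NC(=O)C1CCN(C2CCCC2)CC1`: > 10 mg/kg
compound 2, `COc1cc(N)c(Cl)cc1NC(=O)C1CCN(Cc2ccc(OCc3ccccc3)cc2)CC1`: > 4 mg/kg

Of the compounds shown here, two have been tested in a functional assay on the whole organism for antagonist activity, with Mus musculus as the target; a lower number here means that less compound is needed, a higher number that more compound is needed for the effect. For compound 1 the result is only the limit > 10 mg/kg, a boundary of the assay and not a number. For compound 2 the result is likewise a limit, > 4 mg/kg. Compound 1 therefore stands at the edge of what this assay can resolve (the limit of > 10 mg/kg in this assay, at which 1 of the 2 values shown sits), and compound 2 sits at a limit as well (the limit of > 4 mg/kg in this assay, at which 1 of the 2 values shown sits). Between two limits no step can be counted, so no measured step is available to guide an expectation.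

Compound 3, `COc1cc(N)c(Cl)cc1NC(=O)C1CCN(CC2CCC2)CC1`, has not yet been measured. It differs from compound 1 in one place: cyclobutylmethyl in place of cyclopentyl on an amine nitrogen in a ring. The two compounds contain the same atoms joined differently, so the change is small. Going by the values given here, with no measured step of this kind to lean on, the expectation is that the step from compound 1 to compound 3 will be a step that the limit leaves unreadable from compound 1 to compound 3, which means no change beyond the usual scatter. Compound 3 is thus expected to give 12 mg/kg, with a likely range from 3 mg/kg to 40 mg/kg, and most probably again only a limit.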

Compound 3, dose for half-maximal effect: > 10 mg/kg
Compound 3: only a limit was reported; the forecaster's own chance of this, stated with the estimate: 70%; the middle value is on the limit's open side.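

Compound 1 and compound 3 both end at a limit of this assay and not at a number, so no step can be read between them: the limit of > 10 mg/kg in this assay, at which 2 of the 3 values shown sit.

The compounds shown leave open what dose any of them actually needs in this assay, and whether cyclobutylmethyl in place of cyclopentyl changes that dose at all.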